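From a benzyl ester chain to a simple hydroxy group

A few compounds are considered here, and "the series" means these few. Any claim that something is new, unique, unknown or untested is made for them only; others in the source may bear on it.

Of the compounds shown here, three have been measured so far in a functional assay on the whole organism (Tail, strain ICR) with Mus musculus as the target, in the tail flick test, with a stated time of 120 min, at a dose of 25 umol/kg by the oral route; a lower number here means a weaker effect, a higher number a stronger effect of the compound at the dose given. Compound 1 `C[C@H](NC(=O)CN(c1nc(Cl)nc2[nH]cnc12)C1CC1)C(=O)OCc1ccccc1` gives 36.1% in this assay. Compound 2 `O=C(CN(c1ncnc2c1ncn2C1CCCCO1)C1CC1)N[C@@H](CCC(=O)OCc1ccccc1)C(=O)OCc1ccccc1` gives 20.7%, and compound 3 `NC(=O)C[C@H](NC(=O)CN(c1nc(Cl)nc2[nH]cnc12)C1CC1)C(=O)O` gives 17%. Compound 2 thus stands second highest of the three numbers; its value and that of compound 3 lie within the scatter of each other, while compound 1 stands beyond the scatter above it.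

The unmeasured compound 4 `O=C(CN(c1ncnc2c1ncn2C1CCCCO1)C1CC1)N[C@@H](CO)C(=O)OCc1ccccc1` differs from compound 2 in one place: hydroxy in place of (benzyloxycarbonyl)methyl on a saturated chain carbon, two bonds along the chain from an amide-type nitrogen and a carbonyl carbon. Among the compounds with values here, no pair of measured compounds shows this change, so its effect is not known from the data. The account therefore rests on compound 2 alone; no direction can be read from the numbers given.

Compound 4 is expected to stay close to compound 2, with a step of a number 3.3 percentage points higher from compound 2 to compound 4 (within the scatter) that is estimated to fall within the usual scatter. The estimate for compound 4 in this assay is 24%, with a range from 10% to 42%.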

Compound 4, a percentage reported as activity, at one dose (the size of the read-out at that dose, not a potency): 29.2%
Compound 4: middle estimate off by 5.2 percentage points, on the low side; the measured number falls inside the stated range.
By their numbers in this assay, from the lowest: compounds 3, 2, 4 and 1 (each within the scatter of the next, the first and the last beyond it).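

Within the data shown here, the first reading of this change comes from hydroxy in place of (benzyloxycarbonyl)methyl on a saturated chain carbon, two bonds along the chain from an amide-type nitrogen and a carbonyl carbon, which gives in this assay a number 8.5 percentage points higher from compound 2 to compound 4 (within the scatter) at the dose given. A group of 11 heavy atoms, with its six-membered aromatic ring of carbon only, can thus be replaced by a single oxygen in this series while the two compounds remain within the scatter of each other, so the benzyl ester chain is not shown to be required for the effect at this position. Nothing available explains this result.

On these data alone, what an amine, a carboxylic acid or a longer chain would give on this carbon stays open. So does whether hydroxy would behave in the same way on any other core.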